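Swapping a Sulfonyl for a Phosphate Chain on the Amide

This account rests on a few compounds, and the source may have more. Where it says the series, first, only, none or still open, it means among the compounds named here.

For the measured compounds named here, compound 2 `CC(C)c1onc(-c2c(Cl)cccc2Cl)c1COc1ccc(N(C)Cc2cccc(C(=O)NS(C)(=O)=O)c2)c(C(F)(F)F)n1` is one of two compounds measured in an assay on isolated protein for agonist activity at Bile acid receptor (Homo sapiens), read by FRET (on this read-out lower numbers stand for smaller maximal responses and higher numbers for larger maximal responses), where compound 2 gives 110%. Its only companion, compound 1 `CC(C)c1onc(-c2c(Cl)cccc2Cl)c1COc1ccc(N(C)Cc2cccc(C(=O)O)c2)c(C(F)(F)F)n1`, carries a free acid where compound 2 bears the methanesulfonamide; in this assay compound 1 gives 102%, and the step of a number 8 percentage points higher from compound 1 to compound 2 (within the scatter) lies within the scatter. Compound 3 `CC(C)c1onc(-c2c(Cl)cccc2Cl)c1COc1ccc(N(C)Cc2cccc(C(=O)NCCOP(=O)(O)O)c2)c(C(F)(F)F)n1` keeps the amide of compound 2 but changes what sits on it: a group of 7 heavy atoms (2 carbon, 4 oxygen, 1 phosphorus; no ring) in place of a group of 4 heavy atoms (1 carbon, 2 oxygen, 1 sulfur; no ring), on an amide-type nitrogen. Going by the values given here, no measured step touches this new group, so the single known step, a number 8 percentage points higher from compound 1 to compound 2 (within the scatter), is the only guide: altering the group on the carbonyl carbon left the maximal response unchanged within the scatter. Compound 3 is therefore expected to behave alike, with a number 5 percentage points lower from compound 2 to compound 3 (within the scatter) as a step of no size beyond the scatter, and its estimated value in this assay is 105%, in the range 85% to 125%.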

Compound 3, largest response reached (reported as efficacy), in percent of the reference or control that the assay uses: 114%
Beside the measured number, compound 3's estimate is 9 percentage points below it; the range from low to high includes it.
By their numbers in this assay, from the lowest: compounds 1, 2 and 3 (each within the scatter of the next, the first and the last beyond it).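

In this assay, the amide-type nitrogen carries a much larger group without any loss of maximal response: the group of 7 heavy atoms, with its 2 hydrogen-bond donors, replaces methylsulfonyl and gives a number 4 percentage points higher from compound 2 to compound 3 (within the scatter) for this change. Set against the free acid, the same chain gives a number 12 percentage points higher from compound 1 to compound 3 (beyond the scatter) as the first step here to clear the scatter, although it is only a modest one. Nothing measured here explains these results.

Going by these compounds, it remains open whether the phosphate end of the chain matters, since a chain ending in an amine or a carboxylic acid would be needed to test that. A longer chain on the same nitrogen would show how much more size this position accepts.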